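Removing a Chloro Group from Two Related Cores

The source may report more compounds than this note shows. Statements on the series, on what has been measured and on what is new or still open speak of the compounds shown alone.

Three compounds were tested in a functional assay on OVCAR-3 cells (Homo sapiens) for inhibition, read by sulforhodamine B assay, with a stated time of 48 h, tested at 100 uM; on this read-out lower numbers stand for less inhibition of growth and higher numbers for more inhibition of growth at the one concentration tested. Compound 1 `O=c1c(C(=S)Nc2ccccc2)coc2cc(Cl)ccc12` gives 47%, while compound 2 `O=c1c(C(=S)Nc2ccccc2)coc2cc(Cl)c(Cl)cc12` gives 2%. Compound 3 `O=c1c(C2N=C(c3ccccc3)SS2)coc2cc(Cl)ccc12` gives 91%, the highest of the three; the difference between the core of compound 3 and that of compound 2 is not broken down here. The change from compound 2 to compound 1 is hydrogen in place of chloro on an aromatic carbon and produced a number 45 percentage points higher from compound 2 to compound 1 (beyond the scatter). Compound 4 `O=c1c(C2N=C(c3ccccc3)SS2)coc2ccccc12` carries the same kind of change relative to compound 3, namely (hydrogen in place of chloro on an aromatic carbon), though here the place is not ortho to a chloro group. Compound 3 already reads near full inhibition at 91%, so a comparable rise has little room. The step from compound 3 to compound 4 is expected to be a number 3 percentage points lower from compound 3 to compound 4 (within the scatter), resting on a number 45 percentage points higher from compound 2 to compound 1 (beyond the scatter) and on that ceiling. Compound 4 is therefore estimated at 88%, expected to fall between 70% and 100%.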

Compound 4, percent growth inhibition at one concentration: 11%
The estimate for compound 4 lay 77 percentage points above the measured number, and the stated range ends above it.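

In this assay, hydrogen in place of chloro on an aromatic carbon gave a number 80 percentage points lower from compound 3 to compound 4 (beyond the scatter). The same change therefore did not carry over from one core to the other, in either size or direction: the same change on two cores in this assay, a number 45 percentage points higher (beyond the scatter) from compound 2 to compound 1 and a number 80 percentage points lower (beyond the scatter) from compound 3 to compound 4, 125 percentage points apart, beyond the scatter of two such steps. This shows that in these two pairs the outcome of the change depends on the core that carries it, but two pairs give no rule for the series and do not show which feature of the cores decides the outcome.

The compounds shown leave open whether the reading of compound 3 needs chloro itself. A fluoro, methyl or methoxy group at that place on the core of compound 3 could answer this.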